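Swapping the dichlorophenyl amide for a trifluoromethylphenyl

The source may report more compounds than this note shows. Statements on the series, on what has been measured and on what is new or still open speak of the compounds shown alone.

Compound 1 `CN(C(=O)NC(=O)c1c(Cl)cccc1Cl)c1nc(C(F)(F)F)c(C(=O)N/N=C/c2ccccc2C(F)(F)F)s1` was tested in a functional assay on BCG823 cells (Homo sapiens) for inhibition, read by MTT assay, with a stated time of 72 h (a higher number here means a weaker inhibitor, a lower number a stronger inhibitor), and gave 4.12 ug/mL. Its companion compound 2 `CN(C(=O)NC(=O)c1c(F)cccc1F)c1nc(C(F)(F)F)c(C(=O)N/N=C/c2cc(C(F)(F)F)cc(C(F)(F)F)c2)s1` gave 5.28 ug/mL in this assay; the two numbers lie within the usual scatter of each other, so neither stands apart. Compound 3 `CN(C(=O)NC(=O)c1ccc(C(F)(F)F)cc1)c1nc(C(F)(F)F)c(C(=O)N/N=C/c2ccccc2C(F)(F)F)s1` carries one change from compound 1: 4-(trifluoromethyl)phenyl in place of 2,6-dichlorophenyl on a carbonyl carbon. For the measured compounds named here, no measured pair shows what this change does, so the step can only be expected. Compound 3 is expected to stay close to compound 1, with a step of a 1.2-fold higher number from compound 1 to compound 3 (0.08 log units; within the scatter) in this assay in no particular direction beyond the scatter. Compound 3 is therefore estimated at 5 ug/mL, between 2.2 ug/mL and 12 ug/mL.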

Compound 3, half-maximal inhibitory concentration: 2.53 ug/mL
Estimate against measurement, compound 3: 2.0-fold (0.30 log units) above; measured number inside the range.
By their numbers in this assay, from the lowest: compounds 3, 1 and 2 (each within the scatter of the next, the first and the last beyond it).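

For the compounds shown here, on the carbonyl carbon whose other neighbour is the amide-type nitrogen, compounds 1 and 3 give the first readable single change in this assay: 4-(trifluoromethyl)phenyl in place of 2,6-dichlorophenyl gives a 1.6-fold lower number from compound 1 to compound 3 (0.21 log units; within the scatter) and so stays within the usual scatter. This position therefore accepts an aryl group without chlorine, and with trifluoromethyl instead, while the numbers remain alike.

On these data alone, whether a 4-aminophenyl, a 4-carboxyphenyl or a plain alkyl chain on the same carbonyl carbon would also keep the number in this range stays open. No measurement shown here offers any explanation for the result.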